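Capping the sulfonamide nitrogen: efficacy of compound 3

The compounds below may be only part of what the source reports. "The series", "measured", "known", "first", "only" and "open" are said of these compounds alone.

Measured so far:
compound 1, `CCS(=O)(=O)Nc1cccc2c1CCCC2c1c[nH]cn1`, 71%
compound 2, `CS(=O)(=O)Nc1cccc2c1OCCC2c1c[nH]cn1`, 88%

Both were tested in a functional assay on Urethra with Alpha-1A adrenergic receptor (Oryctolagus cuniculus) as the target; a lower number here means a smaller maximal response, a higher number a larger maximal response. Compound 1 gives the lower of the two numbers; compound 2 stands higher by a margin that is beyond the usual scatter. Compound 3, `CN(c1cccc2c1CCCC2c1c[nH]cn1)S(C)(=O)=O`, has not been measured. It differs from compound 1 in one place: methyl(methylsulfonyl)amino in place of (ethylsulfonyl)amino on an aromatic carbon. Going by the values given here, no measured pair shows the effect of such a change, so the step can only be guessed. A modest drop is expected, a number 11 percentage points lower from compound 1 to compound 3 (beyond the scatter). Compound 3 is expected to reach 60%, somewhere between 35% and 85%.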

Compound 3, largest response reached (reported as efficacy), in percent of the reference or control that the assay uses: 79%
Compound 3: middle estimate off by 19 percentage points, on the low side, and the stated range covers the measured number.
By their numbers in this assay, from the lowest: compounds 1, 3 and 2 (each within the scatter of the next, the first and the last beyond it).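

In this assay, swapping (ethylsulfonyl)amino for methyl(methylsulfonyl)amino gives a number 8 percentage points higher from compound 1 to compound 3 (within the scatter). The entering group has 0 hydrogen-bond donors where the leaving group has 1, so on this core the sulfonamide hydrogen is not required for a sizeable maximal response. Nothing available explains why the response holds.

Open, as far as these compounds go, is whether the methyl on nitrogen or the shorter chain on sulfur matters more, since both differ in this one swap. Also open, from the compounds shown here alone, is how an ethyl or benzyl group on that nitrogen, or a plain amine at this place, would behave.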